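A few compounds are considered here, and "the series" means these few. Any claim that something is new, unique, unknown or untested is made for them only; others in the source may bear on it.

Measured compounds:
Compound 1, `CN(C)c1ccc(C2CC(c3ccc(-n4cncn4)cc3)=NN2)cc1`: -3.3%
Compound 2, `CC(=O)N1N=C(c2ccc(N3CCN(C)CC3)cc2)CC1c1ccc(N(C)C)cc1`: -1.9%

In a functional assay on NCI-H1975 cells (Homo sapiens) for inhibition, read by sulforhodamine B assay, tested at 10 uM (on this read-out lower numbers stand for less inhibition and higher numbers for more inhibition at the one concentration tested (going by the name of the read-out)), compound 2 gives -1.9%, and compound 1 gives -3.3%. The two numbers lie within the scatter of each other, and neither shows inhibition at the one concentration tested. Compound 3, `CC(=O)N1N=C(c2ccc(-n3cncn3)cc2)CC1c1ccc(N(C)C)cc1`, differs from compound 2 in one place: 1H-1,2,4-triazol-1-yl in place of 4-methylpiperazin-1-yl on an aromatic carbon. Compound 3 also shares with compound 1 the same 1H-1,2,4-triazol-1-yl group, so the two measured compounds frame the change from either side. Among the compounds with values here, no measured pair in this set isolates this exchange, so the account rests on the fact that both measured compounds sit at about zero. The step from compound 2 to compound 3 is expected to be a number 0.4 percentage points higher from compound 2 to compound 3 (within the scatter), no more than the scatter in either direction. For compound 3 the expected value in this assay is therefore -1.5%, with a range from -12% to 10%.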

Compound 3, a percentage reported as inhibition, at one concentration (the size of the read-out at that concentration, not a potency): -0.3%
Compound 3: middle estimate off by 1.2 percentage points, on the low side; the range from low to high includes it.
By their numbers in this assay, from the lowest: compounds 1, 2 and 3 (each within the scatter of the next).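

In this assay, putting 1H-1,2,4-triazol-1-yl in place of 4-methylpiperazin-1-yl on the aromatic carbon, para to a large group, gives a number 1.6 percentage points higher from compound 2 to compound 3 (within the scatter) and so does not separate the two compounds. With 1H-1,2,4-triazol-1-yl held fixed, acetyl in place of hydrogen on the ring amine nitrogen gives a number 3 percentage points higher from compound 1 to compound 3 (within the scatter) and likewise does not separate them, so neither change brings out inhibition at the one concentration tested. No measurement at hand offers an explanation for these results.

The compounds shown leave open whether a carboxylic acid or a primary amine on that aromatic carbon would give inhibition in this assay at all. They also leave open whether a longer acyl chain, such as butanoyl, in place of acetyl on the ring nitrogen would do so.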